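The source may hold more compounds than are shown below. What is called first, only, known or untested is meant among the compounds shown, and "the series" means these compounds.

Compound 1 `O=C(Nc1ccc(Oc2ccnc3[nH]ccc23)cc1)c1nn(-c2ccc(Br)cc2)ccc1=O`: 4280 nM
Compound 2 `Cn1ccc2c(Oc3ccc(NC(=O)c4nn(-c5ccc(Cl)cc5)ccc4=O)cc3)ccnc21`: > 60000 nM
Compound 3 `COc1ccc(-n2ccc(=O)c(C(=O)Nc3ccc(Oc4ccnc5c4ccn5C)cc3)n2)cc1`: > 60000 nM

Three compounds built on a shared core were tested in a functional assay on HepG2 cells (Homo sapiens) for cytotoxicity, read by MTT assay, with a stated time of 72 h; on this read-out higher numbers stand for weaker inhibition and lower numbers for stronger inhibition. Compound 1 gives 4280 nM. For compound 2 the result is a limit of the assay, > 60000 nM. For compound 3 the result is likewise a limit, > 60000 nM. Compound 3 therefore stands only at a limit, a position it shares with compound 2, as the limit of > 60000 nM in this assay, at which 2 of the 3 values shown sit, records. For the measured compounds named here, the single measured step that changes one place, a step that the two limits leave unreadable from compound 2 to compound 3, is unreadable because both of its ends are limits.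

Compound 4 `Cn1ccc2c(Oc3ccc(NC(=O)c4nn(-c5ccc(Br)cc5)ccc4=O)cc3)ccnc21` has not yet been measured. It differs from compound 3 by bromo in place of methoxy on an aromatic carbon. Going by the values given here, the only measured step touching this place, a step that the two limits leave unreadable from compound 2 to compound 3, bears on the change but without a readable size. Among the compounds with values here, compound 1 carries the same bromo group but lacks the methyl on the shared core, and it gives 4280 nM; no step connects it to compound 4, so its value can only be noted. Given that the step from compound 2 to compound 3 is unreadable, the expected step of a number no higher from compound 3 to compound 4 (the limit leaves the size open) cannot be given a direction beyond the scatter. Compound 4 is accordingly estimated at 60000 nM, within 15000 nM to 200000 nM.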

Compound 4, half-maximal inhibitory concentration: 39200 nM
Beside the measured number, compound 4's estimate is 1.5-fold (0.18 log units) above it; the range from low to high includes it.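

In this assay, with bromo held fixed, methyl in place of hydrogen on the aromatic nitrogen gives a 9.2-fold higher number from compound 1 to compound 4 (0.96 log units; beyond the scatter), and this is the only step among the compounds shown with a readable size beyond the scatter. On the aromatic carbon para to a large group, bromo yields a measured number where methoxy and chloro on the methylated core yield none, but the comparisons amount only to an at least 1.5-fold lower number from compound 3 to compound 4 (0.18 log units; that floor lies within the scatter) and an at least 1.5-fold lower number from compound 2 to compound 4 (0.18 log units; that floor lies within the scatter), so these floors establish no order among the three groups. Compound 2 and compound 3 each rest on the same limit of the assay, so their true values stay unknown: the limit of > 60000 nM in this assay, at which 2 of the 4 values shown sit.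

The compounds shown leave open whether methyl in place of hydrogen on the aromatic nitrogen has a similar size when chloro or methoxy sits on the aromatic ring, and how a longer chain such as ethyl on that nitrogen would read. They also leave open how an amine or a carboxylic acid in the place of bromo would read in this assay.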